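A few compounds are considered here, and "the series" means these few. Any claim that something is new, unique, unknown or untested is made for them only; others in the source may bear on it.

Values in a functional assay on CCRF-CEM cells (Homo sapiens) for antiproliferative activity, read by trypan blue exclusion, with a stated time of 72 h; a higher number here means a weaker inhibitor, a lower number a stronger inhibitor:
Compound 1 `Cc1ccc(C(=O)NC(N)=O)cc1NC(=O)C(C)Br`: 3360 nM
Compound 2 `Cc1ccc(C(=O)NC(N)=O)cc1NC(=O)C(C)Cl`: > 20000 nM (a limit, not a number)

Compound 2 has no measured value, only the limit > 20000 nM. This places compound 2 at the limit of > 20000 nM in this assay, at which 1 of the 2 values shown sits.

Compound 3 `Cc1ccc(C(=O)NC(N)=O)cc1NC(=O)CCl` differs from compound 2 by one change: hydrogen in place of methyl on a saturated chain carbon bound to a carbonyl carbon and a chlorine atom.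

For the measured compounds named here, no measured step covers this replacement. The nearest evidence is an at least 5.9-fold higher number from compound 1 to compound 2 (0.77 log units; beyond the scatter), a change of halogen on that same chain carbon, and it shows that one change there can move this assay beyond the scatter. It says nothing about the direction of removing the methyl. Starting from a limit, any number obtained for compound 3 would lie on the stronger side, so a moderate shift towards a lower number is expected, though compound 3 may also stay at the limit.

The expected change is an at least 2.2-fold lower number from compound 2 to compound 3 (0.34 log units; beyond the scatter), an estimate only. For compound 3 the estimated value is 9000 nM, with an expected range of 2000 nM to 20000 nM.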

Compound 3, half-maximal inhibitory concentration: 3360 nM
Compound 3: middle estimate off by 2.7-fold (0.43 log units), on the high side; the range from low to high includes it.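

In this assay, for the compounds shown here, hydrogen in place of methyl on a saturated chain carbon bound to a carbonyl carbon and a chlorine atom gives an at least 5.9-fold lower number from compound 2 to compound 3 (0.77 log units; beyond the scatter) and is beyond the scatter, so the methyl on this carbon matters as well as the halogen, which was the only change seen before. On these data alone, compound 2 stands at a limit, not a number, so the true size of that step stays unknown: the limit of > 20000 nM in this assay, at which 1 of the 3 values shown sits. Chloromethyl in place of 1-bromoethyl on a carbonyl carbon gives no change at the digits printed from compound 1 to compound 3 (within the scatter) and lies within the scatter, so among these compounds chloro goes with the weak end of the assay only where the methyl is also present, in compound 2, and not in compound 3.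

The compounds shown leave open how bromomethyl or a longer chain such as 1-chloropropyl would read on this carbonyl carbon. They also leave open whether a halogen is needed on this chain carbon at all, a question that an amine or a hydroxyl group in its place would address.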